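This account rests on a few compounds, and the source may have more. Where it says the series, first, only, none or still open, it means among the compounds named here.

Measured in an ADME assay on L1210/0 cells (Mus musculus) for cytotoxicity, with a stated time of 48 h; on this read-out higher numbers stand for weaker inhibition and lower numbers for stronger inhibition:
- Compound 1 `Nc1ncnc2c1ncn2C[C@@H]1C[C@H](O)c2ccccc21`: > 200000 nM, a limit of the assay and not a number
- Compound 2 `O=c1[nH]c(=O)n([C@H]2C[C@H](O)[C@@H](CO)O2)cc1[N+](=O)[O-]`: 130 nM

Only compound 2 has an actual number in this assay, so it stands as the single firm reference point, at 130 nM. Compound 3 `[N-]=[N+]=NCc1cn([C@H]2C[C@H](O)[C@@H](CO)O2)c(=O)[nH]c1=O` is still to be measured. It has azidomethyl in place of nitro on an aromatic carbon, a change counted as azidomethyl in place of nitro on an aromatic carbon. Within the data shown here, no measured pair shows what a swap at this place does, so any expectation here is loose. The expectation is a clear move towards weaker inhibition, beyond the usual scatter, starting from compound 2 at 130 nM. The expected size of the change is a 23-fold higher number from compound 2 to compound 3 (1.36 log units; beyond the scatter). The estimate for compound 3 is 3000 nM, with an expected range of 200 nM to 60000 nM.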

Compound 3, half-maximal inhibitory concentration: 124000 nM
Beside the measured number, compound 3's estimate is 41-fold (1.62 log units) below it, outside the stated range (above it).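

In this assay, among these compounds, replacing nitro with azidomethyl on this aromatic carbon gives the first measured step at this position: a 950-fold higher number from compound 2 to compound 3 (2.98 log units; beyond the scatter). With the rest of the structure unchanged, this one group separates strong inhibition from weak, so the position is far from indifferent to what it carries. Compound 1 stands at a limit of the assay, not a number, and it differs from the other compounds in more than one place, so it adds no step here: the limit of > 200000 nM in this assay, at which 1 of the 3 values shown sits.

One step cannot show which difference between the two groups matters, since azidomethyl differs from nitro in its atoms, its size and its count of hydrogen-bond acceptors. As far as these compounds go, whether a methyl, an aminomethyl or a carboxylic acid on the same carbon would fall closer to compound 2 or to compound 3 remains open.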